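This account rests on a few compounds, and the source may have more. Where it says the series, first, only, none or still open, it means among the compounds named here.

In a functional assay on PPC-1 cells (Homo sapiens) for antiproliferative activity, read by sulforhodamine B assay (a lower number here means a stronger inhibitor, a higher number a weaker inhibitor), three compounds built on one shared core have been measured. Compound 1 `CCCCCCCCCCCCCCCCCCNC(=O)[C@H]1CSC(c2ccc(N(C)C)cc2)N1` gives 1100 nM, compound 2 `CCCCCCCCCCCCCCCCCCNC(=O)[C@H]1CSC(c2ccc(F)cc2)N1` gives 2100 nM, and compound 3 `CCCCCCCCCCCCCCCCCCNC(=O)[C@H]1CSC(c2ccc([N+](=O)[O-])cc2)N1` gives 15300 nM, the highest number of the three. The step of a 14-fold higher number from compound 1 to compound 3 (1.14 log units; beyond the scatter) and the step of a 7.3-fold higher number from compound 2 to compound 3 (0.86 log units; beyond the scatter) both lie beyond the scatter, so among these compounds the nitro group goes with the weakest inhibition. Compound 4 `CCCCCCCCCCCCCCCCCCNC(=O)[C@H]1CSC(c2ccc(C#N)cc2)N1` differs from compound 3 in one place: cyano in place of nitro on an aromatic carbon. Going by the values given here, both measured steps that brought a nitro group onto this aromatic carbon raised the number, and replacing it with cyano is expected to lower it again, though no measured step shows cyano itself. Compound 4 is therefore estimated at 5000 nM, between 1500 nM and 15000 nM, a step of a 3.1-fold lower number from compound 3 to compound 4 (0.49 log units; beyond the scatter) towards stronger inhibition.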

Compound 4, half-maximal inhibitory concentration: 5000 nM
The estimate for compound 4 equals the measured number at the digits printed; the measured number falls inside the stated range.
By their numbers in this assay, from the lowest: compounds 1 and 2 (each within the scatter of the next); then compound 4; then compound 3.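

In this assay, cyano on this aromatic carbon recovers part of the rise seen with nitro (a 3.1-fold lower number from compound 3 to compound 4 (0.49 log units; beyond the scatter)), so the two groups are not interchangeable here. Cyano still does not reach the numbers of the other two groups (a 2.4-fold higher number from compound 2 to compound 4 (0.38 log units; beyond the scatter); a 4.5-fold higher number from compound 1 to compound 4 (0.66 log units; beyond the scatter)), which places compound 4 apart from all three earlier compounds. Nothing shown here explains why these groups differ. Where a methoxy group or a carboxylic acid on this carbon would fall remains open. So does the effect of a shorter chain in place of the long one.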